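This account rests on a few compounds, and the source may have more. Where it says the series, first, only, none or still open, it means among the compounds named here.

In an ADME assay on HMEC-1 cells (Homo sapiens) for cytotoxicity, read by MTT assay (on this read-out lower numbers stand for stronger inhibition and higher numbers for weaker inhibition), compound 1 (`Cc1cc(CNC(C)(C)C)c(C)n1Nc1ccnc2cc(Cl)ccc12`) is entered as "not determined" (no result reported) and so adds no number to the series. Compound 2 (`Cc1c(CN2CCCC2)cc(-c2ccc(Cl)cc2)n1Nc1ccnc2cc(Cl)ccc12`) gives 7180 nM in this read-out and compound 3 (`Cc1c(CNC[C@@H]2CCCN3CCCC[C@H]23)cc(-c2ccccc2)n1Nc1ccnc2cc(Cl)ccc12`) gives 13500 nM on the same scale. These two values lie within the scatter of each other, so compound 2 has no clear place apart from compound 3 on the numbers available.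

Compound 4 (`Cc1c(CN2CCCC2)cc(-c2ccccc2)n1Nc1ccnc2cc(Cl)ccc12`) has not yet been measured. Its structure departs from that of compound 2 at a single place: the change hydrogen in place of chloro on an aromatic carbon puts hydrogen in place of chloro on an aromatic carbon, turning 4-chlorophenyl into phenyl. Among the measured compounds shown here, the series holds no measured step between two compounds that differ in one place, so nothing shows directly how large this change is in this assay. The estimate therefore stays close to the value of compound 2 and keeps a wide range. The estimated step of a 1.3-fold higher number from compound 2 to compound 4 (0.12 log units; within the scatter) is expected to stay within the scatter, with any drift more likely towards a higher number, meaning weaker inhibition. For compound 4 the estimated value is 9500 nM with an expected range from 4500 nM to 20000 nM in this assay once the measurement is in.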

Compound 4, half-maximal inhibitory concentration: 12900 nM
Estimate against measurement, compound 4: 1.4-fold (0.13 log units) below; the measured number falls inside the stated range.
By their numbers in this assay, from the lowest: compounds 2, 4 and 3 (each within the scatter of the next).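

In this assay, turning 4-chlorophenyl into phenyl gives a 1.8-fold higher number from compound 2 to compound 4 (0.25 log units; within the scatter), so this single change, at the place para to a large group, does not separate the two compounds in this read-out. The second comparison concerns the saturated chain carbon bound to an aromatic carbon, where a group of 5 heavy atoms with one five-membered non-aromatic ring takes the place of a group of 12 heavy atoms with 2 six-membered non-aromatic rings; this gives a 1.0-fold lower number from compound 3 to compound 4 (0.02 log units; within the scatter), so even this much larger difference in the group does not separate the pair. No supporting measurement is available to account for either result.

On these data alone, it remains open whether a group such as methoxy, trifluoromethyl or a carboxylic acid on that aromatic carbon would move the number beyond the scatter. Also open, as far as these compounds go, is whether a morpholine or an open-chain primary amine on the saturated chain carbon would do so, since both steps here stay within the scatter and neither sets a limit on what this position accepts.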